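Aryl amides on a shared chloro-substituted core

This account rests on a few compounds, and the source may have more. Where it says the series, first, only, none or still open, it means among the compounds named here.

Measured so far:
- compound 1 `O=C(Nc1ccc(Cl)c(-c2nnc3c(Cl)cccn23)c1)c1ccc(C(F)(F)F)cc1F`: 41200 nM
- compound 2 `CS(=O)(=O)c1ccc(C(=O)Nc2ccc(Cl)c(-c3nnc4c(Cl)cccn34)c2)c(Cl)c1`: > 100000 nM
- compound 3 `Cc1nc(C(=O)Nc2ccc(Cl)c(-c3nnc4c(Cl)cccn34)c2)cs1`: > 100000 nM

Three amides on the same core have been run in a functional assay on AN3-CA cells (Homo sapiens) for antiproliferative activity, read by MTT assay, with a stated time of 72 h; on this read-out higher numbers stand for weaker inhibition and lower numbers for stronger inhibition. Compound 1 gives a numerical value, 41200 nM. For compound 2 only a limit is reported, > 100000 nM. Compound 3 likewise returns only a limit, > 100000 nM, so its true value is not known; it sits where two of the three results sit (the limit of > 100000 nM in this assay, at which 2 of the 3 values shown sit). Within the data shown here, no step between two measured compounds is available that would show the effect of changing the amide substituent by itself.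

Compound 4 `O=C(Nc1ccc(Cl)c(-c2nnc3c(Cl)cccn23)c1)c1c(F)cccc1Cl` is not yet measured. Relative to compound 3 the change is 2-chloro-6-fluorophenyl in place of 2-methyl-1,3-thiazol-4-yl on a carbonyl carbon. This carries the series back to a carbon-only six-membered aromatic ring bearing halogens, the type that in compound 1 gave a measurable value, 41200 nM. From a limit no step size can be computed, but compound 4 is expected to fall below the limit into the measurable range, with a step of an at least 2.5-fold lower number from compound 3 to compound 4 (0.39 log units; beyond the scatter). Compound 4 is estimated at 40000 nM, between 12000 nM and 100000 nM, with a real chance that only a limit is returned.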

Compound 4, half-maximal inhibitory concentration: > 100000 nM
Compound 4: only a limit was reported; the forecaster's own chance of this, stated with the estimate: 35%; at least 2.5-fold (0.39 log units) between middle value and limit.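

No step can be read between compound 3 and compound 4, as both are reported only as limits: the limit of > 100000 nM in this assay, at which 3 of the 4 values shown sit.

The compounds shown leave open what a change of the amide substituent does by itself, and where the true values of compound 3 and compound 4 lie.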